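Taking a Chloro Away from Compound 2

This account rests on a few compounds, and the source may have more. Where it says the series, first, only, none or still open, it means among the compounds named here.

Measured in an ADME assay on L6 cells (Rattus norvegicus) for cytotoxicity, read by resazurin assay, with a stated time of 70 h (on this read-out lower numbers stand for stronger inhibition and higher numbers for weaker inhibition), are:
compound 1 `CC(=O)Oc1ccc2c(c1)C(C)=CC(C)(C)N2Cc1ccccc1` with 18000 nM
compound 2 `CC(=O)Oc1c(Cl)cc2c(c1Cl)C(C)=CC(C)(C)N2Cc1ccccc1` with 110000 nM
compound 3 `CC(=O)Oc1cc(C)c2c(c1)C(C)=CC(C)(C)N2Cc1ccccc1` with 48000 nM

Of these three, compound 2 has the highest number, lying beyond the scatter from both others. Compound 4 `CC(=O)Oc1cc2c(cc1Cl)N(Cc1ccccc1)C(C)(C)C=C2C` is still unmeasured and differs from compound 2 by hydrogen in place of chloro on an aromatic carbon. Among the compounds with values here, no measured step covers this change directly. The only one available is a 2.7-fold higher number from compound 1 to compound 3 (0.43 log units; beyond the scatter), where methyl replaces hydrogen on an aromatic carbon. Compound 1, which carries no chloro, gives 18000 nM, so a modest move to a lower number is expected in this assay. The expected change is a 2.4-fold lower number from compound 2 to compound 4 (0.39 log units; beyond the scatter). Compound 4 is estimated at 45000 nM, with an expected range from 20000 nM to 100000 nM.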

Compound 4, half-maximal inhibitory concentration: 22000 nM
Compound 4: middle estimate off by 2.0-fold (0.31 log units), on the high side; low and high end bracket the measured number.
By their numbers in this assay, from the lowest: compounds 1 and 4 (each within the scatter of the next); then compound 3; then compound 2.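

In this assay, taking away the chloro that stands ortho to the acetoxy group and ortho to a fused ring gives a 5.0-fold lower number from compound 2 to compound 4 (0.70 log units; beyond the scatter), a step beyond the scatter. The chloro kept in compound 4 gives a 1.2-fold higher number from compound 1 to compound 4 (0.09 log units; within the scatter), which lies within the scatter, so the two chloro groups of compound 2 do not count alike here. Nothing available explains this difference.

The compounds shown leave open how this chloro behaves without the other one. They also leave open whether fluoro or methoxy at this position would resemble hydrogen or chloro.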